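Methoxy to Nitro on a Shared Core: Cytotoxicity Outlook

A few compounds are considered here, and "the series" means these few. Any claim that something is new, unique, unknown or untested is made for them only; others in the source may bear on it.

Compound 1 `COc1ccc(CSc2nc3ccccc3c(=O)[nH]2)cc1` and compound 2 `COc1cccc(CSc2nc3ccccc3c(=O)[nH]2)c1` are made of the same atoms joined differently; the difference between the two cores is not broken down here. Compound 3 `O=c1[nH]c(SCc2cccc([N+](=O)[O-])c2)nc2ccccc12` arises from compound 2 by nitro in place of methoxy on an aromatic carbon. In an ADME assay on MRC5 cells (Homo sapiens) for cytotoxicity, read by neutral red uptake (on this read-out lower numbers stand for higher toxicity in this test and higher numbers for lower toxicity in this test), compound 1 gives > 64000 nM, which is a limit of the assay and not a number. Compound 2 likewise gives only the limit > 64000 nM in this assay. Compound 3 also stops at the limit > 64000 nM in this assay. Accordingly the step that the two limits leave unreadable from compound 2 to compound 3 cannot be read, because of the limit of > 64000 nM in this assay, at which 3 of the 3 values shown sit. Compound 4 `O=c1[nH]c(SCc2ccc([N+](=O)[O-])cc2)nc2ccccc12`, not yet measured, differs from compound 1 by nitro in place of methoxy on an aromatic carbon; this is the same kind of change as from compound 2 to compound 3, though there the nitro stands meta to a large group and here para to a large group. Compound 4 is expected to sit where the three measured compounds sit, resting on (the limit of > 64000 nM in this assay, at which 3 of the 3 values shown sit), so the step that the limit leaves unreadable from compound 1 to compound 4 is estimated. For compound 4 the estimate in this assay is 80000 nM, between 30000 nM and 300000 nM, most likely reported again only as a limit.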

Compound 4, half-maximal cytotoxic concentration: > 64000 nM
Compound 4: no number, only a limit; the forecaster's own chance of this, stated with the estimate: 85%; the middle value lies beyond the limit too.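

In this assay compound 4 gives > 64000 nM, which is a limit of the assay and not a number. The step from compound 1 to compound 4 cannot be read, because the values stop at the same limit: the limit of > 64000 nM in this assay, at which 4 of the 4 values shown sit. The compounds shown leave open whether nitro in place of methoxy changes the cytotoxicity at all, and at what concentration any of these compounds would harm the cells.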